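Sulfonamide aryl swap from bromo to dimethyl

The source may hold more compounds than are shown below. What is called first, only, known or untested is meant among the compounds shown, and "the series" means these compounds.

Compound 1 `COc1ccccc1NS(=O)(=O)c1ccc(N2CCNC2=O)cc1`: 550 nM
Compound 2 `O=C1NCCN1c1ccc(S(=O)(=O)Nc2ccc(I)cc2)cc1`: 650 nM
Compound 3 `O=C1NCCN1c1ccc(S(=O)(=O)Nc2ccc(Br)cc2)cc1`: 300 nM

In a functional assay on HT-29 cells (Homo sapiens) for antiproliferative activity, read by sulforhodamine B assay, with a stated time of 48 h (a higher number here means a weaker inhibitor, a lower number a stronger inhibitor), compound 3 has the lowest number of the three. Its gap to compound 1 is within the scatter, and its step from compound 2 is a 2.2-fold lower number from compound 2 to compound 3 (0.34 log units; beyond the scatter). Compound 4 `Cc1ccc(NS(=O)(=O)c2ccc(N3CCNC3=O)cc2)cc1C` differs from compound 3 as follows: 3,4-dimethylphenyl in place of 4-bromophenyl on a sulfonamide nitrogen. For the measured compounds named here, the steps that bear on this are a 1.8-fold lower number from compound 1 to compound 3 (0.26 log units; within the scatter) and a 1.2-fold higher number from compound 1 to compound 2 (0.07 log units; within the scatter), both within the scatter, showing that the aryl group on the sulfonamide nitrogen has so far moved the number only a little. For compound 4 a step of a 1.5-fold higher number from compound 3 to compound 4 (0.18 log units; within the scatter) is therefore expected, not beyond the scatter. Compound 4 is estimated at 450 nM, with a range of 150 nM to 1400 nM.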

Compound 4, half-maximal inhibitory concentration: 230 nM
Compound 4: middle estimate off by 2.0-fold (0.29 log units), on the high side; the range from low to high includes it.
By their numbers in this assay, from the lowest: compounds 4, 3, 1 and 2 (each within the scatter of the next, the first and the last beyond it).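

In this assay, 3,4-dimethylphenyl on the sulfonamide nitrogen gives a 1.3-fold lower number from compound 3 to compound 4 (0.12 log units; within the scatter), so an aryl group without a halogen can match 4-bromophenyl at this position. The same group gives a 2.8-fold lower number from compound 2 to compound 4 (0.45 log units; beyond the scatter) and a 2.4-fold lower number from compound 1 to compound 4 (0.38 log units; beyond the scatter), both modest but larger than the scatter. No evidence at hand explains these steps. The compounds shown leave open whether the number would hold with an amine or a carboxylic acid on this aryl ring. They also leave open what a longer chain in place of the methyl groups would do.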